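The source may report more compounds than this note shows. Statements on the series, on what has been measured and on what is new or still open speak of the compounds shown alone.

Compound 1 `Cc1ccc(S(=O)(=O)Nc2ccc(-c3nc4ccccc4o3)cc2)cc1`: > 100000 nM in an assay on cells for inhibition of HSP60/HSP10 (Homo sapiens), with a stated time of 60 min; on this read-out lower numbers stand for stronger inhibition and higher numbers for weaker inhibition.
Compound 2 `Cc1ccc(S(=O)(=O)Nc2ccc3oc(-c4ccccc4)nc3c2)cc1`: > 100000 nM.
Compound 3 `O=S(=O)(Nc1ccc(-c2nc3ccccc3o2)cc1)c1ccccc1Cl`: > 100000 nM.

The figure shown above in this assay is not a number but a limit of the assay in the case of compound 2. The same holds for compound 1, and for compound 3, so that every value shown so far sits at the limit of > 100000 nM in this assay, at which 3 of the 3 values shown sit. Among the compounds with values here, the one step between measured compounds that differ in a single place is a step that the two limits leave unreadable from compound 1 to compound 3; it says nothing about how large an exchange of one group for another may weigh here.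

Compound 4 `O=S(=O)(Nc1ccc2oc(-c3ccccc3)nc2c1)c1ccc(Cl)cc1` is still to be measured in this assay. It differs from compound 2 by chloro in place of methyl on an aromatic carbon. Within the data shown here, no measured step bears on this exchange in a readable way, and the three values shown give no sign that any member of this series reaches a number within the window of the assay. The expected step is therefore a step that the limit leaves unreadable from compound 2 to compound 4, nothing beyond the scatter. Compound 4 is thus expected to come out near 150000 nM, within a range from 40000 nM to 600000 nM, most likely again as a limit rather than a number.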

Compound 4, half-maximal inhibitory concentration: > 100000 nM
Compound 4 ended at the assay's limit; the forecaster's own chance of this, stated with the estimate: 85%; the middle value is on the limit's open side.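

Compound 4 also ends at a limit rather than a number, so no step from compound 2 to compound 4 can be read: the limit of > 100000 nM in this assay, at which 4 of the 4 values shown sit.

The compounds shown leave open whether any member of this series gives a number within the window of this assay, and how much any exchange of one group for another weighs there.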